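Shared-core antiproliferative series: truncating the sulfonamide nitrogen

The compounds below may be only part of what the source reports. "The series", "measured", "known", "first", "only" and "open" are said of these compounds alone.

Working notes on three compounds measured in a functional assay on SF-295 cells (Homo sapiens) for antiproliferative activity, read by sulforhodamine B assay, with a stated time of 72 h; a higher number here means a weaker inhibitor, a lower number a stronger inhibitor:

compound 1 `Cc1ccc(C(/C=C/c2ccc(F)cc2)=N\Nc2nncc3ccccc23)cc1` gives 0.55 nM
compound 2 `O=C1CS/C(=N/Nc2nncc3ccccc23)N1c1ccccc1` gives 4.6 nM
compound 3 `Cc1cc(NS(=O)(=O)c2ccc(Nc3nncc4ccccc34)cc2)no1` gives 4.4 nM

Compound 3 stands second highest of the three numbers. Its nearest neighbour is compound 2, whose value lies within the scatter of it, so the two cannot be ordered. Its furthest is compound 1, which sits at a lower number beyond the scatter.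

Compound 4 `NS(=O)(=O)c1ccc(Nc2nncc3ccccc23)cc1` has not yet been measured in this assay. It differs from compound 3 in one place: hydrogen in place of 5-methyl-1,2-oxazol-3-yl on a sulfonamide nitrogen. Among the measured compounds shown here, no pair of measured compounds differs in a single place, so there is no measured step anywhere in the set to anchor the size of this change; the expectation below rests on the value of compound 3 alone and on the nature of the change as counted.

The step from compound 3 is expected to run toward a higher number in this assay, of a size only just beyond the scatter, and a result inside the scatter would not be surprising: a 2.7-fold higher number from compound 3 to compound 4 (0.44 log units; beyond the scatter). Compound 4 is therefore estimated at 12 nM, with a range from 3 nM to 50 nM.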

Compound 4, half-maximal inhibitory concentration: 5.3 nM
Beside the measured number, compound 4's estimate is 2.3-fold (0.35 log units) above it, and the stated range covers the measured number.
By their numbers in this assay, from the lowest: compound 1; then compounds 3, 2 and 4 (each within the scatter of the next).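

In this assay, the series now has its first measured step between compounds that differ in one place, and it lies within the scatter: a 1.2-fold higher number from compound 3 to compound 4 (0.08 log units; within the scatter) on replacing the 5-methyl-1,2-oxazol-3-yl on the sulfonamide nitrogen with hydrogen. At this position, therefore, a group of 6 heavy atoms containing a five-membered aromatic ring can give way to a single hydrogen atom with no readable effect on the number, and the two compounds cannot be ordered. Among the compounds shown here, the measurements show only that this group is not needed for the reading in this assay, and nothing on hand explains that result.

From the compounds shown here alone, it remains open whether a smaller group such as methyl or acetyl on the same nitrogen, or a larger one such as phenyl, would also stay within the scatter of compound 4. A single step likewise cannot show whether a carboxylic acid or an amine in place of the whole sulfonamide would be accommodated as readily, or whether this tolerance would hold on a different core.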